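Adding a second dichloro amide group to the shared core

The source may hold more compounds than are shown below. What is called first, only, known or untested is meant among the compounds shown, and "the series" means these compounds.

Compound 1 `Cc1ccccc1-c1cccc(NC(=O)C(Cl)Cl)c1` gives 31600 nM as its result
Compound 2 `O=C(Nc1cccc(-c2cccc(F)c2)c1)C(Cl)Cl` gives > 50000 nM as its result

In a functional assay on NCI-H460 cells (Homo sapiens) for cytotoxicity, read by MTT assay, with a stated time of 68 h (on this read-out higher numbers stand for weaker inhibition and lower numbers for stronger inhibition), compound 2 gives > 50000 nM as its result, which is a limit and not a number. Compound 3 `O=C(Nc1cccc(-c2cccc(NC(=O)C(Cl)Cl)c2)c1)C(Cl)Cl` carries a ((dichloromethyl)carbonyl)amino group in place of the fluoro of compound 2, on an aromatic carbon, meta to a large group (((dichloromethyl)carbonyl)amino in place of fluoro on an aromatic carbon). Among the measured compounds shown here, no measured pair of closely matched compounds shows what such a swap does in this assay so the size of the step remains uncertain. For the measured compounds named here, the only true number so far is that of compound 1 at 31600 nM and it offers the sole anchor for a guess. A modest move toward lower numbers, meaning stronger inhibition, is expected (an at least 2.2-fold lower number from compound 2 to compound 3 (0.35 log units; beyond the scatter)). Compound 3 is estimated at 22000 nM (expected range 7000 nM to 50000 nM).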

Compound 3, half-maximal inhibitory concentration: > 50000 nM
Compound 3 was reported as a limit; the forecaster's own chance of this, stated with the estimate: 25%; middle value at least 2.2-fold (0.35 log units) from the limit.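

No step can be read from compound 2 to compound 3, because both are reported only as limits and not as numbers: the limit of > 50000 nM in this assay, at which 2 of the 3 values shown sit. On these data alone, whether ((dichloromethyl)carbonyl)amino in place of fluoro changes the result in this assay at all, and in which direction, stays open.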